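The source may report more compounds than this note shows. Statements on the series, on what has been measured and on what is new or still open speak of the compounds shown alone.

In an ADME assay on L02 cells (Homo sapiens) for cytotoxicity, read by MTT assay, with a stated time of 24 h (a lower number here means a stronger inhibitor, a higher number a weaker inhibitor), compound 1 `CN1C/C(=C\c2ccc(C(F)(F)F)cc2)C(=O)/C(=C/c2ccccc2F)C1`, which carries trifluoromethyl, gives 18600 nM, and compound 2 `CN1C/C(=C\c2ccc(F)cc2)C(=O)/C(=C/c2cccc([N+](=O)[O-])c2)C1` gives 17600 nM. Compound 3 `CN1C/C(=C\c2ccc(Cl)cc2)C(=O)/C(=C/c2cccc([N+](=O)[O-])c2)C1` yields no number, only a limit of > 20000 nM. Going by the values given here, it is the one compound at the limit of > 20000 nM in this assay, at which 1 of the 3 values shown sits. Compound 4 `CN1C/C(=C\c2ccc(C(F)(F)F)cc2)C(=O)/C(=C/c2cccc([N+](=O)[O-])c2)C1` differs from compound 3 by trifluoromethyl in place of chloro on an aromatic carbon, with trifluoromethyl in place of chloro on an aromatic carbon. Among the compounds with values here, the one measured step that changes this same substituent is an at least 1.1-fold higher number from compound 2 to compound 3 (0.05 log units; that floor lies within the scatter), and it gives only a floor. No step beyond the scatter can be read from it, so only a small change in this assay is expected, with no firm direction. The closest guide is compound 1 at 18600 nM, which shares the trifluoromethyl group although its other substituent differs. The expected change is an at least 1.1-fold lower number from compound 3 to compound 4 (0.04 log units; that floor lies within the scatter), and it may prove smaller. For compound 4 the estimated value is 18000 nM, with an expected range of 10000 nM to 30000 nM.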

Compound 4, half-maximal inhibitory concentration: 12400 nM
Compound 4: middle estimate off by 1.5-fold (0.16 log units), on the high side; measured number inside the range.
By their numbers in this assay, from the lowest: compounds 4, 2 and 1 (each within the scatter of the next). At a limit, above all of these: compound 3.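

In this assay, a measured number now stands for trifluoromethyl on the aromatic carbon para to a large group: replacing fluoro there gives a 1.4-fold lower number from compound 2 to compound 4 (0.15 log units; within the scatter), and replacing 2-fluorophenyl with 3-nitrophenyl while trifluoromethyl stays gives a 1.5-fold lower number from compound 1 to compound 4 (0.18 log units; within the scatter), so neither change moves the reading past the scatter. Against chloro, the step is only a floor, an at least 1.6-fold lower number from compound 3 to compound 4 (0.20 log units; that floor lies within the scatter). Compound 3 itself is a limit and not a number: the limit of > 20000 nM in this assay, at which 1 of the 4 values shown sits.

As far as these compounds go, how far chloro and trifluoromethyl truly lie apart at this position therefore stays open. The compounds shown carry only fluoro, chloro and trifluoromethyl there, so they leave open how an amine, a carboxylic acid or a longer chain at the same position would read.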